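The source may hold more compounds than are shown below. What is called first, only, known or untested is meant among the compounds shown, and "the series" means these compounds.

Compound 2 `COc1ccc(C[C@H]2COC(=O)[C@@H]2Cc2ccc(OCC(=O)Nc3ccccc3)c(OC)c2)cc1OC` is, in an ADME assay on HeLa cells (Homo sapiens) for cytotoxicity, read by MTT assay (on this read-out lower numbers stand for stronger inhibition and higher numbers for weaker inhibition), reported only as a limit of the assay: compound 2 gives >= 600000 nM. Compound 1 `COc1ccc(C[C@H]2COC(=O)[C@@H]2Cc2ccc(OCc3cn(-c4ccc(Br)cc4)nn3)c(OC)c2)cc1OC` in this assay gives 128000 nM. Among the measured compounds shown here, the single measured step, an at least 4.6-fold higher number from compound 1 to compound 2 (0.67 log units; beyond the scatter), therefore rests in part on (the limit of >= 600000 nM in this assay, at which 1 of the 2 values shown sits). Compound 3 `COc1ccc(C[C@H]2COC(=O)[C@@H]2Cc2ccc(OC(=O)CCC(=O)N3CCCCC3)c(OC)c2)cc1OC` differs from compound 2 by a group of 12 heavy atoms (9 carbon, 1 nitrogen, 2 oxygen; one six-membered non-aromatic ring with 1 hetero atom) in place of a group of 10 heavy atoms (8 carbon, 1 nitrogen, 1 oxygen; one six-membered aromatic ring of carbon only), on an oxygen on an aromatic ring. For the measured compounds named here, no measured step exchanges groups of this kind, and the one known step ends at the limit, so for compound 3 a change of about an at least 1.3-fold lower number from compound 2 to compound 3 (0.12 log units; that floor lies within the scatter) is expected, without a clear direction beyond the scatter. Compound 3 is estimated at 450000 nM in this assay, within 120000 nM to 900000 nM.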

Compound 3, half-maximal inhibitory concentration: 128000 nM
For compound 3 the middle estimate is 3.5-fold (0.55 log units) above the measured one, within the range that was stated.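

In this assay, putting the group with a six-membered non-aromatic ring on this oxygen in place of (phenylcarbamoyl)methyl gives an at least 4.6-fold lower number from compound 2 to compound 3 (0.67 log units; beyond the scatter). Compound 1 gives 128000 nM and compound 3 gives 128000 nM, so two quite different groups at this place print the same value. Compound 2 is reported only as a limit, so this step gives a floor and not a true size: the limit of >= 600000 nM in this assay, at which 1 of the 3 values shown sits.

Which part of the entering group goes with the lower number remains open. Also open, on these data alone, is how a carboxylic acid or an amine at the end of the chain on this oxygen would read.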